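A few compounds are considered here, and "the series" means these few. Any claim that something is new, unique, unknown or untested is made for them only; others in the source may bear on it.

Measured compounds in an assay on HEK293 cells for inhibition of protein kinase C zeta type (Homo sapiens), read by 33P incorporation, with a stated time of 40 min, tested at 20 uM, in the presence of a further agent that is not named here; on this read-out higher numbers stand for more inhibition at the one concentration tested (going by the name of the read-out) and lower numbers for less inhibition:
compound 1, `COc1ccc(C2=NN(c3ccc(Cl)cc3)C(c3ccc(Cl)cc3)C2)cc1OC`, gives 39.4%
compound 2, `COc1ccc(C2=NN(c3cccc(Cl)c3)C(c3cccc(Cl)c3)C2)cc1`, gives 25.3%
compound 3, `COc1ccc(C2=NN(c3ccccc3Cl)C(c3ccccc3Cl)C2)cc1`, gives 9.6%

Compound 3 stands lowest of the three numbers. Its nearest neighbour is compound 2, whose number lies higher by a margin beyond the scatter; compound 1 lies furthest from compound 3, again beyond the scatter. Among the compounds with values here, the three compounds differ from one another in more than one place, so no single step between measured compounds can be read off; only the ordering of their values is known.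

Compound 4, `Nc1ccc(C2=NN(c3ccccc3Cl)C(c3ccccc3Cl)C2)cc1`, is the next member and differs from compound 3 in one place: amino in place of methoxy on an aromatic carbon. Cut one bond further out, the change reads 4-methoxyphenyl to 4-aminophenyl. Within the data shown here, no measured pair shows this change, so the expected step rests only on the single-concentration nature of the read-out and the low starting point of compound 3 at 9.6%. The step is expected to be small, in either direction, and most likely not beyond the scatter, giving an expected change of a number 2.4 percentage points higher from compound 3 to compound 4 (within the scatter). Compound 4 is therefore expected to give about 12% in this assay, with a range from 0% to 30%.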

Compound 4, a percentage reported as inhibition, at one concentration (the size of the read-out at that concentration, not a potency): 31%
Compound 4: middle estimate off by 19 percentage points, on the low side, outside the stated range (above it).
By their numbers in this assay, from the lowest: compound 3; then compounds 2, 4 and 1 (each within the scatter of the next, the first and the last beyond it).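

Amino in place of methoxy on the aromatic carbon, para to a large group, gives a number 21.4 percentage points higher from compound 3 to compound 4 (beyond the scatter) in this assay, and this is the first single-place step in the series. It shows that this position can change the read-out beyond the scatter while the rest of the molecule stays fixed, which the three earlier compounds, differing in more than one place, could not show. The change replaces methoxy, with 2 heavy atoms and 0 hydrogen-bond donors, by amino, with 1 heavy atom and 1 hydrogen-bond donor, but no available measurement indicates which of these differences, if either, accounts for the step.

The compounds shown leave open whether the higher number is specific to amino or is shared by neighbouring groups at this position, such as hydroxyl, methylamino, dimethylamino or acetamido. They also leave open whether the same change gives a similar step with the other chlorine placements on the shared core, and, with one concentration per compound, how the step would translate into potency.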